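Ethyl for methyl on the chain carbon of compound 1

The source may hold more compounds than are shown below. What is called first, only, known or untested is meant among the compounds shown, and "the series" means these compounds.

compound 1 `C[C@H](Nc1ncnc2[nH]cnc12)c1nn(-c2cccnc2)c2cc(F)ccc12` — 23%
compound 2 `C[C@H](Nc1ncnc2[nH]cnc12)c1nn(-c2ccncc2)c2cc(F)ccc12` — 47%

In a functional assay on HepG2 cells (Homo sapiens) for inhibition, read by sulforhodamine B assay, with a stated time of 72 h, tested at 10 uM (a lower number here means less inhibition, a higher number more inhibition at the concentration tested (going by the name of the read-out)), compound 1 gives 23% and compound 2 gives 47%; compound 1 holds the lower of the two numbers, set apart from compound 2 by the step of a number 24 percentage points higher from compound 1 to compound 2 (beyond the scatter). Compound 3 `CC[C@H](Nc1ncnc2[nH]cnc12)c1nn(-c2cccnc2)c2cc(F)ccc12` differs from compound 1 by methyl in place of hydrogen on a saturated chain carbon, two bonds along the chain from an aromatic carbon and a nitrogen on an aromatic ring. Going by the values given here, no measured step touches this saturated chain carbon; the only step at hand swaps the ring on the aromatic nitrogen, so nothing measured tells how this assay responds to the change. The step of no change at the digits printed from compound 1 to compound 3 (within the scatter) is therefore expected to stay within the scatter. Compound 3 is estimated at 23%, between 5% and 45%.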

Compound 3, a percentage reported as inhibition, at one concentration (the size of the read-out at that concentration, not a potency): 26%
For compound 3 the middle estimate is 3 percentage points below the measured one; measured number inside the range.
By their numbers in this assay, from the lowest: compounds 1 and 3 (each within the scatter of the next); then compound 2.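

In this assay, methyl in place of hydrogen on this saturated chain carbon, the methyl to ethyl difference, gives a number 3 percentage points higher from compound 1 to compound 3 (within the scatter). Compounds 1 and 3 cannot be told apart in this read-out, so this chain carbon carries ethyl as well as methyl here, whereas the earlier step concerned only the ring on the aromatic nitrogen. Nothing available gives a reason for this result.

Open, as far as these compounds go, is whether a longer chain such as propyl, or an amine on this carbon, would also fall within the scatter of compound 1. Also open, from the compounds shown here alone, is whether ethyl gives the same outcome alongside the pyridin-4-yl of compound 2.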